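The source may report more compounds than this note shows. Statements on the series, on what has been measured and on what is new or still open speak of the compounds shown alone.

In a physicochemical assay for lipophilicity, read by HPLC, at pH 7.4 (a lower number here means a more polar compound, a higher number a more lipophilic compound), compound 2 is the starting point of this comparison. Compound 2 `Cc1ccnc([C@@H](C)Oc2cc3oc(=O)n(CCC(=O)O)c3cc2Cl)c1` gives 2.15 in this assay. Compound 1 `Cc1ccc([C@@H](C)Oc2cc3onc(CCC(=O)O)c3cc2Cl)nc1` gives 2.42, and the gap between compound 1 and compound 2 lies within the scatter, so the two numbers cannot be told apart. Compound 3 `COc1cc2oc(=O)n(CCC(=O)O)c2cc1Cl` gives "not determined" (no result reported) in this assay, so no number is reported for it. Compound 4 `C[C@@H](Oc1cc2oc(=O)n(CCC(=O)O)c2cc1Cl)c1ncco1` differs from compound 2 by 1,3-oxazol-2-yl in place of 4-methylpyridin-2-yl on a saturated chain carbon bound to an oxygen on an aromatic ring and a saturated chain carbon. Going by the values given here, no measured pair of compounds shows this same change, so the size of the step is not known from the data at hand. With 1,3-oxazol-2-yl in place of 4-methylpyridin-2-yl, the expectation is a step downward beyond the scatter, the estimated step being a number 0.55 log units lower from compound 2 to compound 4 (beyond the scatter). Compound 4 is therefore expected to give 1.6 in this assay, with a range from 1.1 to 2.1.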

Compound 4, distribution coefficient: 1.11
Compound 4: the middle estimate sits 0.49 log units above what was measured; measured number inside the range.
By their numbers in this assay, from the lowest: compound 4; then compounds 2 and 1 (each within the scatter of the next).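

In this assay, going by these compounds alone, the saturated chain carbon bound to an oxygen on an aromatic ring proves sensitive to the ring it carries: 1,3-oxazol-2-yl in place of 4-methylpyridin-2-yl gives a number 1.04 log units lower from compound 2 to compound 4 (beyond the scatter), the first step here between compounds differing in one place. The change replaces a six-membered aromatic ring with 1 hetero atom by a five-membered one with 2 hetero atoms. Nothing at hand explains the size of this step. Ring size and hetero atoms change together, so their shares remain unresolved. A 1,3-thiazol-2-yl or an unsubstituted phenyl at this carbon could help separate them.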